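A few compounds are considered here, and "the series" means these few. Any claim that something is new, unique, unknown or untested is made for them only; others in the source may bear on it.

In a functional assay on A-375 cells (Homo sapiens) for cytotoxicity, read by sulforhodamine B assay, with a stated time of 48 h (on this read-out higher numbers stand for weaker inhibition and lower numbers for stronger inhibition), compound 1 `COc1cc(NC(=O)[C@H]2CSC(c3ccccc3)=N2)cc(OC)c1OC` gives 13600 nM. This is the higher of the two actual numbers in the series. Compound 2 `COc1ccc(-c2nc(C(=O)c3cc(OC)c(OC)c(OC)c3)cs2)cc1OC` gives 34 nM, a gap well beyond the scatter, so compound 1 inhibits far more weakly than compound 2. Compound 3 `COc1cc(NC(=O)[C@@H]2CSC(c3ccccc3)N2)cc(OC)c1OC` reads > 100000 nM in this assay. That reading is a limit of the assay and not a number.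

Still unmeasured is compound 4 `COc1cc(NC(=O)[C@@H]2CSC(c3ccccc3)=N2)cc(OC)c1OC`, which is related to compound 1 by a single change: the two compounds have the same atoms and bonds and differ only in configuration as drawn: 1 of 1 stereo elements differ; a stereocentre at a saturated ring carbon is drawn S in compound 1 and R in compound 4. A stereocentre at a saturated ring carbon is drawn S in compound 1 and R in compound 4, while the atoms and bonds stay the same.

Within the data shown here, no measured pair differs in configuration alone, so the data give no direct guide to the size of this step in this assay. Among the measured compounds shown here, the only anchor is compound 1 at 13600 nM. The working expectation is therefore a small change with no firm direction, probably within the scatter, though a wider move cannot be excluded. The expected change is a 1.2-fold lower number from compound 1 to compound 4 (0.09 log units; within the scatter). For compound 4 the estimated value is 11000 nM, with an expected range of 3000 nM to 40000 nM.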

Compound 4, half-maximal inhibitory concentration: 22800 nM
Beside the measured number, compound 4's estimate is 2.1-fold (0.32 log units) below it; the measured number falls inside the stated range.
By their numbers in this assay, from the lowest: compound 2; then compounds 1 and 4 (each within the scatter of the next). At a limit, above all of these: compound 3.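

In this assay, among these compounds, the first pair that can be read for configuration alone gives a 1.7-fold higher number from compound 1 to compound 4 (0.22 log units; within the scatter). Redrawing the stereocentre at the saturated ring carbon from S in compound 1 to R in compound 4 therefore has no effect here that can be told from the usual scatter, which the earlier compounds could not show. This reading isolates the stereocentre from every other feature, with nothing entering or leaving the structure, so it applies to this single change and to no other: the fact that compounds 1 and 4 differ only in the configuration as drawn.

Compound 3 gives > 100000 nM, which is a limit of the assay and not a number, and no compound shown pairs with it in configuration alone, so whether configuration matters for that structure stays open. Also open, on these data alone, is whether the two configurations remain within the scatter of each other when the shared core carries a further group, such as an amine or a carboxylic acid.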